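Replacing the thiophen-3-yl of compound 3 with iodo

The source may report more compounds than this note shows. Statements on the series, on what has been measured and on what is new or still open speak of the compounds shown alone.

Of the compounds shown here, three of a shared core have been measured in a functional assay on HCT-116 cells (Homo sapiens), read by MTT assay, with a stated time of 72 h; a higher number here means a weaker inhibitor, a lower number a stronger inhibitor. Compound 1 `COc1ncnc2c1c(I)cn2[C@@H]1O[C@H](CO)[C@@H](O)[C@H]1O` carries iodo and a methoxy group; in this assay compound 1 reaches only a limit, > 20000 nM. Compound 2 `Cc1ncnc2c1c(-c1cccs1)cn2[C@@H]1O[C@H](CO)[C@@H](O)[C@H]1O` carries a thiophen-2-yl group; in this assay compound 2 likewise reaches only a limit, > 20000 nM. For the measured compounds named here, compound 3 `Cc1ncnc2c1c(-c1ccsc1)cn2[C@@H]1O[C@H](CO)[C@@H](O)[C@H]1O` carries a thiophen-3-yl group and in this assay gives 1430 nM, the only real number among the three, the other two sitting at the limit of > 20000 nM in this assay, at which 2 of the 3 values shown sit. Going by the values given here, the single measured step, an at least 13-fold lower number from compound 2 to compound 3 (1.14 log units; beyond the scatter), shows the aromatic group to matter.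

Compound 4 `Cc1ncnc2c1c(I)cn2[C@@H]1O[C@H](CO)[C@@H](O)[C@H]1O` is now considered; it differs from compound 3 by iodo in place of thiophen-3-yl on an aromatic carbon. Among the compounds with values here, no measured step covers this exchange directly. Compound 1, the other iodo compound, stands at a limit, and compound 2 shows a smaller aromatic change already costing much, so a sizeable loss is expected: the step of a 10-fold higher number from compound 3 to compound 4 (1.02 log units; beyond the scatter) is the estimate. Compound 4 is therefore expected at 15000 nM, within 3000 nM to 50000 nM, and may well reach only a limit.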

Compound 4, half-maximal inhibitory concentration: 7570 nM
Estimate against measurement, compound 4: 2.0-fold (0.30 log units) above; the range from low to high includes it.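

In this assay, the thiophen-3-yl group proves not to be indispensable at this aromatic carbon: iodo in its place costs only part of the activity, giving a 5.3-fold higher number from compound 3 to compound 4 (0.72 log units; beyond the scatter). Iodo also compares favourably with thiophen-2-yl at the same carbon, with an at least 2.6-fold lower number from compound 2 to compound 4 (0.42 log units; beyond the scatter), so the order of these three groups does not follow their count of heavy atoms. The other group on the core counts as well, since methyl in place of methoxy gives an at least 2.6-fold lower number from compound 1 to compound 4 (0.42 log units; beyond the scatter), and this step and the one before it are bounds only: the limit of > 20000 nM in this assay, at which 2 of the 4 values shown sit.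

The compounds shown leave open whether an amine or a phenyl ring at this carbon would improve on compound 3, at 1430 nM. They also leave open whether methyl and methoxy differ in the same way when thiophen-3-yl takes the place of iodo.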